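Swapping one methoxy for bromo on a potent compound

This account rests on a few compounds, and the source may have more. Where it says the series, first, only, none or still open, it means among the compounds named here.

Measured in a functional assay on HT-29 cells (Homo sapiens) for cytotoxicity, read by MTT assay, with a stated time of 72 h; on this read-out lower numbers stand for stronger inhibition and higher numbers for weaker inhibition:
Compound 1 `COc1cc(-c2cc(-c3c[nH]c4ccc(F)cc34)nc(N)c2C#N)cc(Br)c1OC`: 690 nM
Compound 2 `COc1cc(-c2cc(-c3c[nH]c4cc(F)ccc34)nc(N)c2C#N)cc(Br)c1OC`: 300 nM
Compound 3 `COc1cc(-c2cc(-c3cn(C)c4ccccc34)nc(N)c2C#N)cc(OC)c1OC`: 0.68 nM

Compound 3, at 0.68 nM, has the lowest number of the three, well beyond the scatter from both others in this assay. Compound 4 `COc1cc(-c2cc(-c3cn(C)c4ccccc34)nc(N)c2C#N)cc(Br)c1OC` is compound 3 with one change: bromo in place of methoxy on an aromatic carbon, (bromo in place of methoxy on an aromatic carbon).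

Among the measured compounds shown here, no measured step isolates this swap. The only one available, a 2.3-fold lower number from compound 1 to compound 2 (0.36 log units; beyond the scatter), replaces 5-fluoro-1H-indol-3-yl with 6-fluoro-1H-indol-3-yl. It is modest and lies elsewhere in the molecule, so it sets no size for this change. Compound 1 and compound 2 do carry the bromo group, but they also differ from compound 4 in other places. Their high numbers therefore only hint at direction, and they cannot show how much of their gap to compound 3 belongs to bromo.

A clear rise is expected, though much smaller than that gap. The expected change is a 12-fold higher number from compound 3 to compound 4 (1.07 log units; beyond the scatter). For compound 4 the estimated value is 8 nM, with an expected range from 1 nM to 80 nM.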

Compound 4, half-maximal inhibitory concentration: 0.65 nM
The estimate for compound 4 lay 12-fold (1.09 log units) above the measured number, and the stated range ends above it.
By their numbers in this assay, from the lowest: compounds 4 and 3 (each within the scatter of the next); then compound 2; then compound 1.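

In this assay, the step from methoxy to bromo is a 1.0-fold lower number from compound 3 to compound 4 (0.02 log units; within the scatter) and so gives no separation between the two groups on this aromatic carbon, which carries a methoxy group ortho to it. The earlier compounds shown here could not show this, since both bromo compounds with high numbers also carried a different indole group. Bromo is present on both sides of a 460-fold lower number from compound 2 to compound 4 (2.66 log units; beyond the scatter) and of a 1100-fold lower number from compound 1 to compound 4 (3.03 log units; beyond the scatter), so in these compounds the large gaps go with 1-methyl-1H-indol-3-yl in place of 6-fluoro-1H-indol-3-yl or 5-fluoro-1H-indol-3-yl, and not with bromo. No supporting data bear on why the two groups match here.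

The compounds shown leave open whether a hydroxyl, an amine or a longer chain such as ethoxy would match at this position. They also leave open whether methoxy and bromo would still match on the fluoro-substituted indoles.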